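The source may report more compounds than this note shows. Statements on the series, on what has been measured and on what is new or still open speak of the compounds shown alone.

Compounds measured in a functional assay on A549 cells (Homo sapiens) for cytotoxicity, read by MTT assay; a higher number here means a weaker inhibitor, a lower number a stronger inhibitor:

compound 1, `CCCCOC(=O)Nc1ccc(S(=O)(=O)N2C[C@H](c3ccccc3)NC2=O)cc1CC` — 200 nM
compound 2, `CCOC(=O)Nc1ccc(S(=O)(=O)N2C(=O)N[C@@H](c3ccccc3)C2C)cc1Cl` — 6000 nM
compound 3, `Cc1cc(S(=O)(=O)N2C(=O)N[C@@H](c3ccccc3)C2C)ccc1NC(=O)c1ccc([N+](=O)[O-])cc1` — > 10000 nM

Compound 1 stands lowest of the two numbers in this assay. The nearest value is that of compound 2, which gives 6000 nM, a gap that lies beyond the usual scatter. Within the data shown here, compound 3 is reported only as a limit, > 10000 nM, and not as a number; it is the one value that sits at the limit of > 10000 nM in this assay, at which 1 of the 3 values shown sits. No pair among these three differs in a single place, so no measured step can be read from them.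

Compound 4, `CCc1cc(S(=O)(=O)N2C[C@H](c3ccccc3)NC2=O)ccc1NC(=O)OC(C)C`, is the partner of compound 1 in the step followed here. The two differ in one place: isopropyl in place of butyl on an oxygen next to a carbonyl group. The butyl chain gives way to an isopropyl group on the oxygen next to the carbonyl, with the rest of the molecule, including the (isopropoxycarbonyl)amino in place of the (butoxycarbonyl)amino, otherwise unchanged. Among the measured compounds shown here, with no measured step on this kind of exchange to lean on, compound 4 is expected to stay close to compound 1, the step of a 1.3-fold higher number from compound 1 to compound 4 (0.10 log units; within the scatter) falling within the scatter. Compound 4 is therefore estimated at 250 nM, between 100 nM and 700 nM, in this assay.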

Compound 4, half-maximal inhibitory concentration: 60 nM
Beside the measured number, compound 4's estimate is 4.2-fold (0.62 log units) above it; measured number below the stated range.
By their numbers in this assay, from the lowest: compound 4; then compound 1; then compound 2. At a limit, above all of these: compound 3.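

Isopropyl in place of butyl on an oxygen next to a carbonyl group gives a 3.3-fold lower number from compound 1 to compound 4 (0.52 log units; beyond the scatter) in this assay. This is the first single-place comparison among the compounds shown, and it indicates that the response in this assay depends on the group carried on that oxygen, a point the earlier compounds, none of which differed in only one place, could not address. Nothing measured here accounts for the size or direction of this step.

One exchange cannot separate the effect of branching from that of removing a carbon, so a straight propyl chain or a tert-butyl group on the same oxygen would be needed to tell the two apart. On these data alone, whether the same exchange would act alike on the core of compound 2 also remains open.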